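Swapping a hydroxyalkyl group for an amino ester chain

This account rests on a few compounds, and the source may have more. Where it says the series, first, only, none or still open, it means among the compounds named here.

Measured so far:
- compound 1, `CCCCCNc1cccc2c(S(=O)(=O)Nc3onc(C)c3C)cccc12`: 80 nM
- compound 2, `CNc1cccc2c(S(=O)(=O)Nc3onc(C)c3C)cccc12`: 130 nM
- compound 3, `Cc1noc(NS(=O)(=O)c2cccc3c(C(C)(C)O)cccc23)c1C`: 2890 nM

In an assay on VSM-A10 cells for antagonist activity at Endothelin-1 receptor (Rattus norvegicus) (a higher number here means a weaker inhibitor, a lower number a stronger inhibitor), compound 3 gives the highest number of the three, the weakest inhibitor in this set. Compound 4, `CCOC(=O)C(C)Nc1cccc2c(S(=O)(=O)Nc3onc(C)c3C)cccc12`, is not yet measured; it differs from compound 3 by (1-(ethoxycarbonyl)ethyl)amino in place of 1-hydroxy-1-methylethyl on an aromatic carbon. The two measured steps that bear on this change both run the other way: a 36-fold higher number from compound 1 to compound 3 (1.56 log units; beyond the scatter) and a 22-fold higher number from compound 2 to compound 3 (1.35 log units; beyond the scatter), each large and beyond the scatter. Both show that an amino-linked chain at this position goes with a much lower number than the 1-hydroxy-1-methylethyl group, and that the length of that chain matters little, as a 1.6-fold higher number from compound 1 to compound 2 (0.21 log units; within the scatter) is within the scatter. Compound 4 carries an amino-linked chain again, so a large drop in this assay is expected, roughly a 19-fold lower number from compound 3 to compound 4 (1.28 log units; beyond the scatter). The estimate for compound 4 is therefore 150 nM, with a range from 40 nM to 600 nM.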

Compound 4, half-maximal inhibitory concentration: 400 nM
For compound 4 the middle estimate is 2.7-fold (0.43 log units) below the measured one; the range from low to high includes it.
By their numbers in this assay, from the lowest: compounds 1 and 2 (each within the scatter of the next); then compound 4; then compound 3.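

In this assay, returning to an amino link at this position gives a 7.2-fold lower number from compound 3 to compound 4 (0.86 log units; beyond the scatter), yet this does not bring the number back to that of the simpler amino chains. The group on the nitrogen therefore matters more than methyl and pentyl alone suggested: 1-(ethoxycarbonyl)ethyl in place of methyl gives a 3.1-fold higher number from compound 2 to compound 4 (0.49 log units; beyond the scatter) and in place of pentyl gives a 5.0-fold higher number from compound 1 to compound 4 (0.70 log units; beyond the scatter), although methyl and pentyl lie within the scatter of each other. No measurement here gives a reason for this difference.

The compounds shown leave open whether the ester, the branching methyl or both set the higher number. A carboxylic acid in place of the ethyl ester, or an unbranched chain ending in an ethyl ester, would help separate these.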